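The source may report more compounds than this note shows. Statements on the series, on what has been measured and on what is new or still open speak of the compounds shown alone.

Of the compounds shown here, two have so far been measured in an assay on membranes from HEK293 cells for displacement of a labelled ligand from adenosine receptor A2b (Homo sapiens), read by scintillation counting, with a stated time of 30 min, tested at 1 uM; on this read-out lower numbers stand for less inhibition and higher numbers for more inhibition at the one concentration tested (going by the name of the read-out). Compound 1 `CC(=O)C1=C(C)NC(=O)NC1c1ccsc1` gives 24% in this assay. Compound 2 `CCC(CC)OC(=O)C1=C(C)NC(=O)NC1c1ccoc1` gives 28% in this assay. Compound 2 stands beside compound 1 on these numbers: the gap between the two lies within the usual scatter of repeated measurements, so neither can be told apart from the other. Compound 3 `CCC(CC)OC(=O)C1=C(C)NC(=O)NC1c1ccsc1` has not yet been measured. It differs from compound 2 in one place: thiophen-3-yl in place of furan-3-yl on a saturated ring carbon. Compound 1 already carries thiophen-3-yl and gives 24% in this assay, a number within the scatter of that of compound 2, so the swap shows no sign of shifting the read-out. The step of a number 2 percentage points lower from compound 2 to compound 3 (within the scatter) is therefore expected to be small, not beyond the scatter. Compound 3 is estimated to give 26%, with a range from 10% to 45%.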

Compound 3, a percentage reported as inhibition, at one concentration (the size of the read-out at that concentration, not a potency): 26%
Beside the measured number, compound 3's estimate shows no gap at the digits printed; measured number inside the range.
By their numbers in this assay, from the lowest: compounds 1, 3 and 2 (each within the scatter of the next).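

In this assay, thiophen-3-yl in place of furan-3-yl on a saturated ring carbon gives a number 2 percentage points lower from compound 2 to compound 3 (within the scatter), so the two five-membered aromatic rings cannot be told apart at this position. Compounds 1 and 2 differ in two places, so they could not show this, and compound 3 now also isolates the other place: (pentan-3-yl)oxy in place of methyl on a carbonyl carbon gives a number 2 percentage points higher from compound 1 to compound 3 (within the scatter), which again leaves the pair indistinguishable. No measurement shown here offers a reason for either result.

Still open, going by these compounds, is whether phenyl or an amine on that saturated ring carbon would give a number beyond the scatter. The same question stands for a hydroxyl or a longer chain in place of (pentan-3-yl)oxy on the carbonyl carbon.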